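A Double Bond Turned in a Barely Active Series

The compounds below may be only part of what the source reports. "The series", "measured", "known", "first", "only" and "open" are said of these compounds alone.

For the measured compounds named here, in a functional assay on WiDr cells (Homo sapiens) for antiproliferative activity, read by sulforhodamine B assay, with a stated time of 48 h (on this read-out lower numbers stand for stronger inhibition of growth and higher numbers for weaker inhibition of growth), compound 2 `CC(C)(C)[Si](C)(C)O[C@@H]1CCCO[C@@H]1/C=C/C(=O)OCc1ccccc1` gives 90000 nM, the only true number so far. Compound 1 `CC(C)(C)[Si](C)(C)OC[C@H]1OCCC[C@H]1O[Si](C)(C)C(C)(C)C` reports only a limit, > 100000 nM. Compound 3 `O=C(/C=C/[C@H]1OCCC[C@H]1O)OCc1ccccc1` also reports only a limit, > 100000 nM. This small set therefore sits close to the limit of > 100000 nM in this assay, at which 2 of the 3 values shown sit, and compound 2 offers little room to read any trend.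

Compound 4 `CC(C)(C)[Si](C)(C)O[C@@H]1CCCO[C@@H]1/C=C\C(=O)OCc1ccccc1` is the next to be tested, and it differs from compound 2 in a single respect: the two compounds have the same atoms and bonds and differ only in configuration as drawn: 1 of 3 stereo elements differ; a double bond is drawn E in compound 2 and Z in compound 4. Going by the values given here, the one measured step, an at least 1.1-fold higher number from compound 2 to compound 3 (0.04 log units; that floor lies within the scatter), removes the silicon-bearing group on an oxygen and leaves the double bond as it was. Among the compounds with values here, no measurement yet tests a change of double bond geometry, so no step size can be carried over directly. With compound 2 at 90000 nM, the reasonable expectation is little change. Another report of only a limit, this time for compound 4, would be no surprise. The expected step is a 1.1-fold lower number from compound 2 to compound 4 (0.02 log units; within the scatter), which would not stand out from the scatter of repeat measurements. For compound 4 the estimated value is 85000 nM, with an expected range from 40000 nM to 100000 nM.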

Compound 4, concentration for 50% growth inhibition: 20000 nM
Beside the measured number, compound 4's estimate is 4.3-fold (0.63 log units) above it; the whole stated range lies above it.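

In this assay, for the compounds shown here, the turn of the double bond gives a 4.5-fold lower number from compound 2 to compound 4 (0.65 log units; beyond the scatter), the first step in this set that can be told apart from the scatter of repeat measurements. The earlier step, an at least 1.1-fold higher number from compound 2 to compound 3 (0.04 log units; that floor lies within the scatter), could not show that, and it also ended at a limit rather than a true number. Nothing enters or leaves the structure here, so the change in activity can be tied to the drawn geometry of this one double bond alone: the fact that compounds 2 and 4 differ only in the configuration as drawn.

The compounds shown leave open whether the Z geometry brings the same gain when the silicon-bearing group gives way to a free hydroxyl on the ring oxygen's neighbouring carbon skeleton, as in compound 3, and whether the step is specific to this pair or holds more widely across the series. They also leave open how a carboxylic acid or an amide in place of the benzyl ester would behave with the double bond drawn Z, given that compound 4, at 20000 nM, still needs a high concentration to slow growth.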